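The source may report more compounds than this note shows. Statements on the series, on what has been measured and on what is new or still open speak of the compounds shown alone.

Measured so far:
compound 1 `Cc1c(OCCCCOc2cccc(F)c2F)ccc(C(=O)CC(C)C)c1O` — 384 nM
compound 2 `Cc1c(OCCCCOc2ccncc2)ccc(C(=O)CC(C)C)c1O` — 3860 nM

In a functional assay for binding affinity to metabotropic glutamate receptor 2 (Homo sapiens), read by GTPgammaS binding (on this read-out lower numbers stand for an effect already at smaller amounts and higher numbers for an effect only at larger amounts of compound), compound 1 stands lowest of the two, with compound 2 giving 3860 nM after a change at a different place: a 10-fold higher number from compound 1 to compound 2 (1.00 log units; beyond the scatter). Compound 3 `CC(C)CC(=O)c1ccc(OCCCCOc2cccc(F)c2F)c(Br)c1O` is not yet measured. It differs from compound 1 by bromo in place of methyl on an aromatic carbon. For the measured compounds named here, no measured step touches this position, so the data give no guide to its size or direction. Absent such a guide, a change within the usual scatter is expected, a 1.0-fold higher number from compound 1 to compound 3 (0.02 log units; within the scatter), placing compound 3 at an estimated 400 nM in this assay, between 130 nM and 1200 nM.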

Compound 3, half-maximal effective concentration: 558 nM
The estimate for compound 3 lay 1.4-fold (0.14 log units) below the measured number; the measured number falls inside the stated range.
By their numbers in this assay, from the lowest: compounds 1 and 3 (each within the scatter of the next); then compound 2.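

In this assay, bromo in place of methyl on the aromatic carbon ortho to the hydroxy group gives a small step (a 1.5-fold higher number from compound 1 to compound 3 (0.16 log units; within the scatter)), so these two groups cannot be told apart at this position. For the compounds shown here, this is the first reading on this position, and it shows that a methyl group is not required here for a number like that of compound 1. Nothing available explains why the two groups read alike. As far as these compounds go, how an amine or a methoxy group would read here remains open. So does whether bromo would read the same with pyridin-4-yl in place of 2,3-difluorophenyl.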